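This account rests on a few compounds, and the source may have more. Where it says the series, first, only, none or still open, it means among the compounds named here.

Measured compounds:
- Compound 1 `COc1cccc(S(=O)(=O)c2cnc3cc(F)ccc3c2-c2cccc(Cl)c2)c1` gives 2.97 mL/min in an ADME assay on microsomes from liver (Homo sapiens) for metabolic stability, tested at 2.5 uM; on this read-out lower numbers stand for slow clearance and higher numbers for fast clearance.
- Compound 2 `O=S(=O)(c1cc(F)cc(F)c1)c1cnc2cc(F)ccc2c1-c1cccc(Cl)c1` gives 0.22 mL/min in this assay.
- Compound 3 `O=S(=O)(c1cc(Cl)cc(Cl)c1)c1cnc2cc(F)ccc2c1-c1cccc(Cl)c1` gives 0.93 mL/min in this assay.

All three share one core and differ only in the group on the sulfonyl sulfur. Among them compound 3 stands second highest: the step of a 3.2-fold lower number from compound 1 to compound 3 (0.50 log units; beyond the scatter) places it well under compound 1, and the step of a 4.2-fold higher number from compound 2 to compound 3 (0.63 log units; beyond the scatter) places it well over compound 2. The remaining step, a 14-fold lower number from compound 1 to compound 2 (1.13 log units; beyond the scatter), shows how wide the spread at this position can be.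

Compound 4 `Cc1ccc(S(=O)(=O)c2cnc3cc(F)ccc3c2-c2cccc(Cl)c2)cc1F` is the next variation at the same position. The change is 3-fluoro-4-methylphenyl in place of 3,5-dichlorophenyl on a sulfonyl sulfur. Within the data shown here, no measured step swaps a 3,5-dichlorophenyl for a 3-fluoro-4-methylphenyl, so the expectation rests on the general finding that changes at this position moved the number by modest to large amounts, in both directions. For compound 4 a step of a 1.6-fold higher number from compound 3 to compound 4 (0.21 log units; within the scatter) in this assay is expected, that is a moderately higher number, with wide uncertainty. The estimate for compound 4 is 1.5 mL/min, expected to fall between 0.5 mL/min and 4.5 mL/min.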

Compound 4, intrinsic clearance in a liver preparation (reported as CLH), per the amount of preparation that the assay uses: 2.13 mL/min
Compound 4: the middle estimate sits 1.4-fold (0.15 log units) below what was measured; the measured number falls inside the stated range.
By their numbers in this assay, from the lowest: compound 2; then compound 3; then compounds 4 and 1 (each within the scatter of the next).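

In this assay, the 3-fluoro-4-methylphenyl group on the sulfonyl sulfur gives a clearly higher number than either the 3,5-dichlorophenyl group (a 2.3-fold higher number from compound 3 to compound 4 (0.36 log units; beyond the scatter)) or the 3,5-difluorophenyl group (a 9.7-fold higher number from compound 2 to compound 4 (0.99 log units; beyond the scatter)). Against the 3-methoxyphenyl group the change stays within the scatter (a 1.4-fold lower number from compound 1 to compound 4 (0.14 log units; within the scatter)), so these two groups cannot be told apart on this read-out. Earlier, both replacements of the 3-methoxyphenyl group lowered the number, but compound 4 goes against that pattern, so such a replacement does not lower it every time.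

No measurement shown accounts for these differences. Still open, on these data alone, is whether the fluorine or the methyl of compound 4 sets its number, and where a ring carrying an amine or a carboxylic acid would fall.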